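A few compounds are considered here, and "the series" means these few. Any claim that something is new, unique, unknown or untested is made for them only; others in the source may bear on it.

Of the compounds shown here, two of this selenium-bearing series have been measured in an ADME assay on MCF-10A cells (Homo sapiens) for cytotoxicity, read by MTT assay, with a stated time of 72 h; on this read-out lower numbers stand for stronger inhibition of growth and higher numbers for weaker inhibition of growth. Compound 1 `C[Se]/C(=N\C(=O)c1cnc2ccccc2c1)NC(=O)c1cnc2ccccc2c1` gives 20300 nM in this assay. Compound 2 `O=C(/N=C(/NC(=O)c1cc2ccccc2s1)[Se]Cc1ccccc1)c1cc2ccccc2s1`, which carries another core and a benzyl group on the selenium, gives 37900 nM in this assay. The two values lie within the scatter of each other, so compound 1 stands on a par with compound 2 and no ordering is supported. Among the measured compounds shown here, no single-point step between them exists, as they differ in more than one place.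

Compound 3 `O=C(/N=C(/NC(=O)c1cnc2ccccc2c1)[Se]Cc1ccccc1)c1cnc2ccccc2c1` has not been measured. It differs from compound 1 by phenyl in place of hydrogen on a saturated chain carbon bound to a selenium atom. For the measured compounds named here, no measured pair isolates this change. Because compound 2 gives 37900 nM with a benzyl group on selenium, though on another core, the expectation for a 1.2-fold higher number from compound 1 to compound 3 (0.09 log units; within the scatter) is no step beyond the scatter. Compound 3 is therefore estimated at 25000 nM in this assay, with a range from 10000 nM to 60000 nM.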

Compound 3, concentration for 50% growth inhibition: 23600 nM
The estimate for compound 3 lay 1.1-fold (0.03 log units) above the measured number, and the stated range covers the measured number.
By their numbers in this assay, from the lowest: compounds 1, 3 and 2 (each within the scatter of the next).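

Among the compounds shown here, on the shared core of compound 1, methyl to benzyl gives a 1.2-fold higher number from compound 1 to compound 3 (0.07 log units; within the scatter) in this assay, the first reading of a change in one place. The saturated chain carbon bound to a selenium atom therefore takes one six-membered aromatic ring of carbon only with no step beyond the scatter, something compound 2 could not show, as it differs from compound 1 in more than one place. No other data on this series bear on this result.

Still open, on these data alone, is whether a longer chain, an amine or a carboxylic acid in place of the benzyl group would give a step beyond the scatter. Also open is whether methyl to benzyl reads the same on the core of compound 2, where no methyl partner is shown.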